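A Bromopyridyl Swap on an Oxadiazole Ketone

This account rests on a few compounds, and the source may have more. Where it says the series, first, only, none or still open, it means among the compounds named here.

Compound 1, `O=C(CCCCCc1ccccc1)c1nc2cccc(F)c2o1`: > 10000 nM
Compound 2, `O=C(CCCCCCc1ccccc1)c1ncc(-c2ccc(C(=O)C(F)(F)F)cc2)o1`: > 10000 nM
Compound 3, `O=C(CCCCCCc1ccccc1)c1nc(-c2ccco2)no1`: 933 nM

Three ketones were tested in an assay on HEK-293T cells for inhibition of diacylglycerol lipase-alpha (Homo sapiens), read by colorimetric assay; a lower number here means a stronger inhibitor, a higher number a weaker inhibitor. For compound 1 the result is a limit of the assay, > 10000 nM. For compound 2 the result is likewise a limit, > 10000 nM. Compound 3 is the only one of the three with a number, 933 nM. Compounds 1 and 2 share (the limit of > 10000 nM in this assay, at which 2 of the 3 values shown sit).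

Compound 4, `O=C(CCCCCCc1ccccc1)c1nc(-c2cccc(Br)n2)no1`, differs from compound 3 by 6-bromopyridin-2-yl in place of furan-2-yl on an aromatic carbon. For the measured compounds named here, no step between measured compounds is available, so the size of this change can only be guessed; compound 4 is expected to stay near compound 3, with the step of a 1.3-fold lower number from compound 3 to compound 4 (0.12 log units; within the scatter) expected to lie at the edge of the scatter. Compound 4 is estimated at 700 nM, within 150 nM to 4000 nM.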

Compound 4, half-maximal inhibitory concentration: 2040 nM
Estimate against measurement, compound 4: 2.9-fold (0.46 log units) below, within the range that was stated.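

In this assay, placing 6-bromopyridin-2-yl in place of furan-2-yl on this aromatic carbon gives a 2.2-fold higher number from compound 3 to compound 4 (0.34 log units; beyond the scatter), a modest step beyond the scatter. Compound 4 still gives a measured number rather than a limit, so a six-membered aromatic ring bearing bromine is accepted at this position. Nothing measured here gives a cause for this step.

The compounds shown leave open whether the bromine or the pyridine ring accounts for the step, as a plain pyridin-2-yl group is not among them. Going by these compounds, whether an amine in place of the bromine would change the number also stays open.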